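The source may hold more compounds than are shown below. What is called first, only, known or untested is meant among the compounds shown, and "the series" means these compounds.

Measured so far in a functional assay on B16-F10 cells (Mus musculus) for antiproliferative activity, read by MTT assay, with a stated time of 48 h; on this read-out higher numbers stand for weaker inhibition and lower numbers for stronger inhibition:
compound 1 `COc1ccc(/C=C/c2cc(OC)cc(OC)c2/C=C/C(=O)c2cccc(Br)c2)cc1` gives 5.1 ug/mL
compound 2 `COc1ccc(/C=C/c2cc(OC)cc(OC)c2/C=C/C(=O)c2ccc(N)cc2)cc1` gives 2.8 ug/mL
compound 3 `COc1ccc(/C=C/c2cc(OC)cc(OC)c2/C=C/C(=O)c2ccc(C)c(C)c2)cc1` gives 1.4 ug/mL

Compound 1 stands with the highest number of the three. The nearest is a 1.8-fold lower number from compound 1 to compound 2 (0.26 log units; within the scatter); the furthest is a 3.6-fold lower number from compound 1 to compound 3 (0.56 log units; beyond the scatter). Between the other two the step is a 2.0-fold lower number from compound 2 to compound 3 (0.30 log units; within the scatter). All three share the same core and differ only in the aryl group on the carbonyl carbon.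

Compound 4 `COc1ccc(/C=C/c2cc(OC)cc(OC)c2/C=C/C(=O)c2ccc(Cl)cc2)cc1` is the next member, not yet measured in this assay. Against compound 1 the change is 4-chlorophenyl in place of 3-bromophenyl on a carbonyl carbon. Going by the values given here, no measured step exchanges one halogenated phenyl for another, so the only bearing comes from the two steps out of compound 1, one within the scatter and one modest, both toward lower numbers. A step of at most that order is expected here, if anywhere toward a lower number, with no firm basis for more than scatter. The step expected for compound 4 is a 1.3-fold lower number from compound 1 to compound 4 (0.11 log units; within the scatter). Compound 4 is expected to give 4 ug/mL, within 2 ug/mL to 8 ug/mL.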

Compound 4, half-maximal inhibitory concentration: 4.9 ug/mL
Beside the measured number, compound 4's estimate is 1.2-fold (0.09 log units) below it, within the range that was stated.
By their numbers in this assay, from the lowest: compounds 3, 2, 4 and 1 (each within the scatter of the next, the first and the last beyond it).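

In this assay, the exchange of 3-bromophenyl for 4-chlorophenyl on the carbonyl carbon gives a 1.0-fold lower number from compound 1 to compound 4 (0.02 log units; within the scatter), so these two halogenated phenyl groups cannot be told apart here. The 3,4-dimethylphenyl group now stands apart from both halogenated phenyl groups, with a 3.5-fold higher number from compound 3 to compound 4 (0.54 log units; beyond the scatter), while the exchange of amino for chloro on the aromatic carbon gives a 1.8-fold higher number from compound 2 to compound 4 (0.24 log units; within the scatter) and separates nothing. No measured property is at hand to account for any of these steps.

The halogen and its place on the ring change together in this pair, so their contributions cannot be separated; a 4-bromophenyl or a 3-chlorophenyl group would divide them. As far as these compounds go, whether a single methyl group, as in 4-methylphenyl, matches the 3,4-dimethylphenyl result of compound 3 also stays open, as does the outcome with a methoxy group or a carboxylic acid on the ring.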